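The source may hold more compounds than are shown below. What is called first, only, known or untested is meant among the compounds shown, and "the series" means these compounds.

Measured in a functional assay on SH-SY5Y cells (Homo sapiens) for cytotoxicity, read by MTT assay, with a stated time of 72 h; a higher number here means a weaker inhibitor, a lower number a stronger inhibitor:
- Compound 1 `O=C1c2c[n+]([O-])c3ccccc3c2C(=O)c2c1c1ccccc1n2Cc1cn(CC(O)CO)nn1`: > 1000 nM, a limit.
- Compound 2 `O=C1c2c[n+]([O-])c3ccccc3c2C(=O)c2c1c1ccccc1n2CCN1CCCC1`: 520 nM.
- Compound 3 `O=C1c2c[n+]([O-])c3ccccc3c2C(=O)c2c1c1ccccc1n2Cc1cn(C[C@@H](O)CO)nn1`: > 500 nM, a limit.

Compound 3 is known only as a limit, > 500 nM. Compound 4 `O=C1c2c[n+]([O-])c3ccccc3c2C(=O)c2c1c1ccccc1n2CCCN1CCC(O)CC1` differs from it as follows: 2-(4-hydroxypiperidin-1-yl)ethyl in place of 1-(2,3-dihydroxypropyl)-1H-1,2,3-triazol-4-yl on a saturated chain carbon bound to an aromatic nitrogen. Thus 2-(4-hydroxypiperidin-1-yl)ethyl stands in place of 1-(2,3-dihydroxypropyl)-1H-1,2,3-triazol-4-yl. The nearest measured change, which removes the same group, is an at least 1.9-fold lower number from compound 1 to compound 2 (0.28 log units; that floor lies within the scatter). The other change of this kind cannot be sized: a step that the limit leaves unreadable from compound 2 to compound 3. A modest move toward a lower number is therefore expected, and compound 2, at 520 nM, serves as the anchor. The expected change is an at least 1.2-fold lower number from compound 3 to compound 4 (0.09 log units; that floor lies within the scatter). Compound 4 is expected at 400 nM, with an estimated range from 120 nM to 1300 nM.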

Compound 4, half-maximal inhibitory concentration: 130 nM
For compound 4 the middle estimate is 3.1-fold (0.49 log units) above the measured one, within the range that was stated.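

In this assay, for the compounds shown here, the 3-(4-hydroxypiperidin-1-yl)propyl chain gives the first steps at this place that lie beyond the scatter: an at least 3.8-fold lower number from compound 3 to compound 4 (0.58 log units; beyond the scatter) and an at least 7.6-fold lower number from compound 1 to compound 4 (0.88 log units; beyond the scatter). Both are floors, as compounds 1 and 3 are known only as limits. The change also reads in full against the pyrrolidine side chain, with a 4.0-fold lower number from compound 2 to compound 4 (0.60 log units; beyond the scatter), so the choice of amine and chain matters even where both compounds carry a saturated amine ring. Ring and chain length change together in that step, so which of them carries it stays open. A morpholine or an unsubstituted piperidine on either chain length would separate the two.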